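A Hydrazone Variant of the Shared Core on MCF7 Cells

The compounds below may be only part of what the source reports. "The series", "measured", "known", "first", "only" and "open" are said of these compounds alone.

Of the compounds shown here, three built on one shared core have been measured. Compound 1 `CCOC(=O)C1=C(N/N=C(/Br)c2ccccc2)Nc2[nH]nc(C)c2C1c1ccc(N(C)C)cc1` gives 78400 nM in a functional assay on MCF7 cells (Homo sapiens) for inhibition, read by MTT assay, with a stated time of 48 h; a lower number here means a stronger inhibitor, a higher number a weaker inhibitor. Compound 2 `CCOC(=O)C1=C(N/N=C(\C#N)C(N)=O)Nc2[nH]nc(C)c2C1c1ccc(N(C)C)cc1` gives 50100 nM in this assay, and compound 3 `CCOC(=O)C1=C(N/C=N/c2ccc([N+](=O)[O-])cc2)Nc2[nH]nc(C)c2C1c1ccc(N(C)C)cc1` gives 58600 nM. Compound 3 stands second highest of the three numbers, with compound 2 nearest and compound 1 furthest; the step of a 1.2-fold higher number from compound 2 to compound 3 (0.07 log units; within the scatter) and the step of a 1.3-fold lower number from compound 1 to compound 3 (0.13 log units; within the scatter) both lie within the scatter, as does the step of a 1.6-fold lower number from compound 1 to compound 2 (0.19 log units; within the scatter), so the three compounds cannot be ordered against each other.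

Compound 4 `CCOC(=O)C1=C(N/N=C(/C(=O)Br)c2ccc(Br)cc2)Nc2[nH]nc(C)c2C1c1ccc(N(C)C)cc1` differs from compound 3 in one place: a group of 12 heavy atoms (8 carbon, 1 nitrogen, 1 oxygen, 2 bromine; one six-membered aromatic ring of carbon only) in place of a group of 11 heavy atoms (7 carbon, 2 nitrogen, 2 oxygen; one six-membered aromatic ring of carbon only), on an amine nitrogen. The step that bears most on this change is a 1.3-fold lower number from compound 1 to compound 3 (0.13 log units; within the scatter), since compound 1 likewise carries a hydrazone bearing a bromine and a phenyl ring on that nitrogen; the other two steps were also within the scatter. No step beyond the scatter is therefore expected, and the estimated step of a 1.2-fold higher number from compound 3 to compound 4 (0.08 log units; within the scatter) reflects this. Compound 4 is expected to give 70000 nM in this assay, with a range from 30000 nM to 160000 nM.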

Compound 4, half-maximal inhibitory concentration: 61300 nM
Estimate against measurement, compound 4: 1.1-fold (0.06 log units) above; the measured number falls inside the stated range.
By their numbers in this assay, from the lowest: compounds 2, 3, 4 and 1 (each within the scatter of the next).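

In this assay, among these compounds, compound 4 does not separate from any of the earlier compounds: the steps are a 1.0-fold higher number from compound 3 to compound 4 (0.02 log units; within the scatter), a 1.2-fold higher number from compound 2 to compound 4 (0.09 log units; within the scatter) and a 1.3-fold lower number from compound 1 to compound 4 (0.11 log units; within the scatter). The amine nitrogen has now carried four different groups, with and without a ring, and the group of 12 heavy atoms with its two bromines and its carbonyl adds no step beyond the scatter, so no group at this position can be ranked against another. Nothing measured here offers an account of this flat result.

From the compounds shown here alone, whether an amine, a carboxylic acid or a longer alkyl chain in this place would move the number beyond the scatter stays open. Going by these compounds, all four numbers come from this assay alone, so whether the same holds in any other read-out is also open.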